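Swapping Fluoro for Tert-Butyl on Compound 3

The compounds below may be only part of what the source reports. "The series", "measured", "known", "first", "only" and "open" are said of these compounds alone.

The three measured compounds share the core of compound 1 `O=C(O)CCc1cccc2c1B(O)OC2`. In a functional assay on HCT-116 cells (Homo sapiens) for antiproliferative activity, read by MTT assay, with a stated time of 72 h (a lower number here means a stronger inhibitor, a higher number a weaker inhibitor), compound 1 gives only a limit, > 100000 nM. Compound 2 `O=C(CCc1cccc2c1B(O)OC2)NCc1ccccc1` likewise gives only a limit in this assay, > 100000 nM. Going by the values given here, compound 3 `O=C(CCc1cccc2c1B(O)OC2)Nc1ccc(F)cc1` is the one compound with a number, 650 nM, and the step of an at least 150-fold lower number from compound 2 to compound 3 (2.18 log units; beyond the scatter) is large. That step, the only measured one, sits on the amide nitrogen, and two of the three values rest at the limit (the limit of > 100000 nM in this assay, at which 2 of the 3 values shown sit), so the measured evidence says little about groups on the aromatic ring itself.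

Compound 4 `CC(C)(C)c1ccc(NC(=O)CCc2cccc3c2B(O)OC3)cc1` differs from compound 3 by tert-butyl in place of fluoro on an aromatic carbon. Among the compounds with values here, no measured step touches a substituent in that position, so the expectation for compound 4 rests on compound 3 alone and the step of a 1.2-fold higher number from compound 3 to compound 4 (0.09 log units; within the scatter) is expected to stay within the scatter, with some risk of a weaker number. Compound 4 is therefore estimated at 800 nM, between 150 nM and 5000 nM.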

Compound 4, half-maximal inhibitory concentration: 19000 nM
Estimate against measurement, compound 4: 24-fold (1.38 log units) below; the measured number lies above the stated range.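

The position on the aromatic ring that holds fluoro in compound 3 had not been touched by any earlier step, and it proves far from indifferent: in this assay, tert-butyl in place of fluoro gives a 29-fold higher number from compound 3 to compound 4 (1.47 log units; beyond the scatter), so the number responds strongly to this ring substituent as well as to the group on the amide nitrogen. Even so, compound 4 still gives a measured number rather than a limit, so this change weakens the compound without taking it out of the measurable range of the assay. Nothing shown here bears on why this step is so large.

With only fluoro and tert-butyl at this position, the compounds shown leave open how a chlorine atom, a methyl group or a methoxy group there would read. Also open, as far as these compounds go, is how an amine or a carboxylic acid at this position would compare with fluoro.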